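A few compounds are considered here, and "the series" means these few. Any claim that something is new, unique, unknown or untested is made for them only; others in the source may bear on it.

The measured compounds:

Compound 1, `OC1CCCN(C(=S)Sc2c(-c3ccc(Br)cc3)[nH]c3ccccc23)C1` — in a functional assay on B16-F10 cells (Mus musculus) for inhibition, read by MTT assay, with a stated time of 72 h (a higher number here means a weaker inhibitor of growth, a lower number a stronger inhibitor of growth), compound 1 gives 29000 nM.
Compound 2, `CCOC(=O)C1CCN(C(=S)Sc2c(-c3ccc(Br)cc3)[nH]c3ccccc23)CC1` — in this assay compound 2 gives 27000 nM.
Compound 3, `OC1CCCN(C(=S)Sc2c(-c3ccc(Br)cc3)[nH]c3ccc(Cl)cc23)C1` — in this assay compound 3 gives 37000 nM.

Compound 3 differs from compound 1 by one change, (chloro in place of hydrogen on an aromatic carbon), and this change gave a 1.3-fold higher number from compound 1 to compound 3 (0.11 log units; within the scatter). Compound 2 carries a different core; how its core differs from that of compound 1 is not broken down here. The values of compound 1 and compound 2 lie close together.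

Compound 4, `CCOC(=O)C1CCN(C(=S)Sc2c(-c3ccc(Br)cc3)[nH]c3ccc(Cl)cc23)CC1`, has not yet been measured in this assay. It differs from compound 2 by chloro in place of hydrogen on an aromatic carbon, the same change that turns compound 1 into compound 3. Because compound 1 to compound 3 gave a 1.3-fold higher number from compound 1 to compound 3 (0.11 log units; within the scatter), the step from compound 2 to compound 4 is expected to be similar in size, a 1.3-fold higher number from compound 2 to compound 4 (0.11 log units; within the scatter). Compound 4 is therefore expected to give about 35000 nM, plausibly between 18000 nM and 70000 nM.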

Compound 4, concentration for 50% growth inhibition: 21000 nM
Compound 4: the middle estimate sits 1.7-fold (0.22 log units) above what was measured; low and high end bracket the measured number.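

The chloro group in place of hydrogen gave a 1.3-fold lower number from compound 2 to compound 4 (0.11 log units; within the scatter) in this assay. Set beside the same change on the other core, this step cannot be told apart from the earlier one: the same change on two cores in this assay, a 1.3-fold higher number (0.11 log units; within the scatter) from compound 1 to compound 3 and a 1.3-fold lower number (0.11 log units; within the scatter) from compound 2 to compound 4, 1.6-fold (0.21 log units) apart, within the scatter of two such steps. This shows that the change stayed within the scatter on both cores, but it does not show that its direction truly reverses between them, nor that it would stay this small on any core beyond these two.

The compounds shown leave open whether a different group on that aromatic carbon, such as fluoro, methoxy or an amine, would give a step beyond the scatter.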